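The source may report more compounds than this note shows. Statements on the series, on what has been measured and on what is new or still open speak of the compounds shown alone.

Working notes on the series in an ADME assay on HepG2 cells (Homo sapiens) for cytotoxicity, read by luminescence and ATP content, with a stated time of 48 h; a higher number here means a weaker inhibitor, a lower number a stronger inhibitor. Of the compounds shown here, two have been read so far. Compound 1 `CC(=O)OCC1(COC(C)=O)OC(=O)C(c2ccc(Br)cc2)=C1c1ccc(C)cc1` gives only a limit of the assay, > 40000 nM. Compound 2 `COc1ccc(C2=C(c3ccc(OC)c(OC)c3)C(CO)OC2=O)cc1` gives only a limit as well, > 40000 nM. Compound 2 thus stands where both values shown stand: at the limit of > 40000 nM in this assay, at which 2 of the 2 values shown sit. Going by the values given here, no step between measured compounds is available, so nothing can yet be said about how a structural change moves the read-out in this assay.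

Compound 3 `COc1ccc(C2=C(c3ccc(OC)c(OC)c3)C(CO)(CO)OC2=O)cc1` has not been measured. It differs from compound 2 by hydroxymethyl in place of hydrogen on a saturated ring carbon, in words a hydroxymethyl in place of hydrogen on a saturated ring carbon; the rest of compound 2 is kept. Among the compounds with values here, with no measured step to lean on, the expectation rests on compound 2 alone, whose value > 40000 nM is a limit. A step of no size beyond the usual scatter is expected for compound 3, and the most likely outcome is that this assay again reports a limit rather than a number. The estimate for compound 3 is 60000 nM, with a range of 20000 nM to 200000 nM. The expected step that the limit leaves unreadable from compound 2 to compound 3 is therefore none beyond the scatter.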

Compound 3, half-maximal inhibitory concentration: > 40000 nM
Compound 3: no number, only a limit; the forecaster's own chance of this, stated with the estimate: 85%; the middle value lies beyond the limit too.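

In this assay compound 3 gives only a limit, > 40000 nM. Going by these compounds alone, compound 2 also gives only a limit, so no step from hydroxymethyl in place of hydrogen on a saturated ring carbon can be read: the limit of > 40000 nM in this assay, at which 3 of the 3 values shown sit. The compounds shown leave open which structural change, if any, would yield a measurable number in this assay.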